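The compounds below may be only part of what the source reports. "The series", "measured", "known", "first", "only" and "open" are said of these compounds alone.

In a functional assay on ileum for inhibition of histamine H1 receptor (Cavia porcellus) (a lower number here means a stronger inhibitor, a higher number a weaker inhibitor), compound 1 `CCOCCn1c(N2CCN(C)CC2)nc2ccccc21` gives 10 nM. Within the data shown here, compound 2 `CCCN1CCN(c2nc3ccccc3n2CCOCC)CC1` gives 16 nM in this assay, the highest of the two numbers measured so far, with compound 1 as its nearest neighbour. Among the measured compounds shown here, the only step measured between them is a 1.6-fold higher number from compound 1 to compound 2 (0.20 log units; within the scatter); that step came with ethyl in place of hydrogen on a saturated chain carbon bound to an amine nitrogen in a ring.

Compound 3 `CCOCCn1c(N2CCNCC2)nc2ccccc21` has not yet been measured. It differs from compound 2 by hydrogen in place of propyl on an amine nitrogen in a ring. For the measured compounds named here, the step of a 1.6-fold higher number from compound 1 to compound 2 (0.20 log units; within the scatter) is the one measured change at this same ring nitrogen, and it lengthened the substituent without moving the number beyond the scatter. Taking the substituent away entirely, leaving a hydrogen on the ring amine nitrogen, is a change that no measured pair covers, so the expectation rests on that single small step and carries a wide range. No step beyond the scatter is expected in this assay. Compound 3 is therefore estimated at 20 nM, with a range from 5 nM to 80 nM. This estimate means an expected step of a 1.3-fold higher number from compound 2 to compound 3 (0.10 log units; within the scatter).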

Compound 3, half-maximal inhibitory concentration: 11 nM
Compound 3: the middle estimate sits 1.8-fold (0.26 log units) above what was measured, within the range that was stated.
By their numbers in this assay, from the lowest: compounds 1, 3 and 2 (each within the scatter of the next).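

In this assay the ring amine nitrogen now has a case with no carbon group on it at all: hydrogen in place of propyl gives a 1.5-fold lower number from compound 2 to compound 3 (0.16 log units; within the scatter) and hydrogen in place of methyl gives a 1.1-fold higher number from compound 1 to compound 3 (0.04 log units; within the scatter) on the same shared core. Both steps lie within the scatter, so hydrogen, methyl and propyl on this nitrogen cannot be told apart, and among these three compounds a carbon group at this position is neither needed for the activity seen nor harmful up to the size of propyl. Nothing available here explains why the numbers stay so close at this nitrogen.

The three compounds leave open how far this flat picture extends, since a group much larger than propyl, such as benzyl or a longer chain, might or might not keep the number where it is. From the compounds shown here alone, it is also open what a different kind of group on this nitrogen would do, such as an acetyl group, which would turn the amine into an amide, or a chain ending in a carboxylic acid.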